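Tert-Butyl in Place of Ethyl: A Step Carried Forward

The source may hold more compounds than are shown below. What is called first, only, known or untested is meant among the compounds shown, and "the series" means these compounds.

Three compounds were measured in an assay on mitochondria from L6 cells (Rattus norvegicus) for activation, with a stated time of 90 min; on this read-out higher numbers stand for an effect only at larger amounts of compound and lower numbers for an effect already at smaller amounts:

Compound 1, `CCc1cccc(Nc2nc3nonc3nc2O)c1`: 25200 nM
Compound 2, `CCc1ccc(Nc2nc3nonc3nc2O)cc1`: 10700 nM
Compound 3, `CC(C)(C)c1cccc(Nc2nc3nonc3nc2O)c1`: 2200 nM

Compound 1 and compound 2 are built from the same atoms joined differently; the difference between the two cores is not broken down here. Compound 3 relates to compound 1 by a single change, (tert-butyl in place of ethyl on an aromatic carbon), and that change gave an 11-fold lower number from compound 1 to compound 3 (1.06 log units; beyond the scatter). Compound 2 stands between the other two in this assay, with a higher number than compound 3 and a lower one than compound 1.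

Compound 4, `CC(C)(C)c1ccc(Nc2nc3nonc3nc2O)cc1`, has not yet been measured. It relates to compound 2 by tert-butyl in place of ethyl on an aromatic carbon. This is the same kind of change as that from compound 1 to compound 3, but not the same: in the measured pair the tert-butyl sits meta to a large group, in the new pair it sits para to a large group.

For the measured compounds named here, because the only precedent is the step from compound 1 to compound 3, an 11-fold lower number from compound 1 to compound 3 (1.06 log units; beyond the scatter), the account expects a step of similar direction for compound 4, estimated at an 8.9-fold lower number from compound 2 to compound 4 (0.95 log units; beyond the scatter) in this assay, with wider uncertainty since the placement differs. Compound 4 is accordingly estimated at 1200 nM, expected to fall between 350 nM and 4500 nM.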

Compound 4, half-maximal effective concentration: 3900 nM
Estimate against measurement, compound 4: 3.3-fold (0.51 log units) below, and the stated range covers the measured number.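

In this assay the change of ethyl to tert-butyl lowered the number on both cores. The new pair gave a 2.7-fold lower number from compound 2 to compound 4 (0.44 log units; beyond the scatter) and so matched the earlier pair in direction, which means that, across these two pairs, the sign of the step carried over from the core of compound 1 to the core of compound 2. For the compounds shown here, with only two pairs, this does not show that the direction would hold on any further core, and the compounds offer no means of telling why the two steps differ in size, since the placement of the group on the ring is the only visible difference between the pairs and it cannot be separated from anything else that distinguishes them. The size of the step did not carry over, so in this series the earlier step could be used as a guide to direction but not as a measure of how large the next step would be: the same change on two cores in this assay, an 11-fold lower number (1.06 log units; beyond the scatter) from compound 1 to compound 3 and a 2.7-fold lower number (0.44 log units; beyond the scatter) from compound 2 to compound 4, 4.2-fold (0.62 log units) apart, beyond the scatter of two such steps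

The compounds shown leave open whether groups other than ethyl and tert-butyl, such as a longer chain, an amine or a carboxylic acid, would follow the same direction at these two placements. They also leave open whether the gap between the two steps would persist for such groups, or whether it is particular to the change from ethyl to tert-butyl.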